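The source may report more compounds than this note shows. Statements on the series, on what has been measured and on what is new or still open speak of the compounds shown alone.

The series shares one core, seen in compound 1 `Nc1cc(N)c2nc(-c3ccccc3)c(NCc3ccc(Cl)c(Cl)c3)nc2c1`, which in a functional assay on TK-10 cells (Homo sapiens) for inhibition, read by sulforhodamine B assay, with a stated time of 48 h (a higher number here means that more compound is tolerated, a lower number that less compound is tolerated), gives 72400 nM. Compound 2 `CCOC(=O)[C@H](CCC(=O)O)NC(=O)c1ccc(Sc2nc3cc(N)cc(N)c3nc2-c2ccccc2)cc1` also belongs to the set. In this assay compound 2 returns only a limit, < 100000 nM. Compound 3 `Nc1cc(N)c2nc(-c3ccccc3)c(Sc3ccc(F)cc3)nc2c1` puts a 4-fluorophenyl on the sulfur. For compound 3 this assay likewise reports only a limit, < 100000 nM, so no number places it within the set. Two of the three values shown sit at that same limit (the limit of < 100000 nM in this assay, at which 2 of the 3 values shown sit), and compound 1 alone has a measured number, which leaves the thioethers of the set without a numerical anchor.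

Compound 4 `Nc1cc(N)c2nc(-c3ccccc3)c(Sc3ccc(Cl)c(Cl)c3)nc2c1` differs from compound 3 in one place: 3,4-dichlorophenyl in place of 4-fluorophenyl on a sulfur. No measured pair in the set isolates this exchange, so its size can be read from nothing shown; compound 1 carries the 3,4-dichlorophenyl on a different connecting group and cannot serve as a direct reference. The step expected in this assay is therefore a step that the limit leaves unreadable from compound 3 to compound 4, nothing beyond the usual scatter, with the result likely to land at or near the limit again. Compound 4 is estimated at 75000 nM in this assay, within a range of 30000 nM to 130000 nM.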

Compound 4, concentration lethal to 50% of the cells: 53700 nM
Compound 4: the middle estimate sits 1.4-fold (0.15 log units) above what was measured; the range from low to high includes it.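

No size can be given for the exchange between compound 3 and compound 4 in this assay, since compound 3 has only a limit there: the limit of < 100000 nM in this assay, at which 2 of the 4 values shown sit.

The compounds shown leave open whether 3,4-dichlorophenyl and 4-fluorophenyl on a sulfur differ at all in this assay, and by how much.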